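Swapping Methyl for Methoxy: From Compound 1 to Compound 3

This account rests on a few compounds, and the source may have more. Where it says the series, first, only, none or still open, it means among the compounds named here.

Compound 1 `CSc1ccc(C)cc1NCC1=NCCN1` stands highest of the two maximal responses measured so far: in a functional assay for agonist activity at Alpha-1D adrenergic receptor (Homo sapiens) (on this read-out higher numbers stand for larger maximal responses and lower numbers for smaller maximal responses), compound 1 gives 107%. Compound 2 `CSc1cc(F)ccc1NCC1=NCCN1` gives 75% in this assay, a gap that lies beyond the usual scatter. Compound 3 `COc1ccc(SC)c(NCC2=NCCN2)c1` has not yet been measured. It differs from compound 1 by methoxy in place of methyl on an aromatic carbon. Within the data shown here, no measured pair shows this kind of change, so there is nothing to lean on for its direction. A step of no size beyond the scatter is expected, a number 7 percentage points lower from compound 1 to compound 3 (within the scatter). Compound 3 is therefore estimated at 100% in this assay, within a range from 80% to 115%.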

Compound 3, largest response reached (reported as maximum), in percent of the reference or control that the assay uses: 91%
Beside the measured number, compound 3's estimate is 9 percentage points above it; low and high end bracket the measured number.
By their numbers in this assay, from the lowest: compound 2; then compound 3; then compound 1.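

Among these compounds, this is the first measured change at this position, the aromatic carbon para to the methylsulfanyl group. In this assay, methoxy in place of methyl gives a modest but real drop, a number 16 percentage points lower from compound 1 to compound 3 (beyond the scatter), so the group here does affect the maximal response. Even so, compound 3 keeps a large response at 91%, so this position accepts the larger methoxy group. No available evidence explains the drop.
The compounds shown leave open how an amine, a hydroxyl group or a longer chain such as ethoxy at this position would change the response.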